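Swapping the methylcarbamoyl of compound 2 for a thiazolyl ring

The source may hold more compounds than are shown below. What is called first, only, known or untested is meant among the compounds shown, and "the series" means these compounds.

Measured so far:
Compound 1 `c1ccc(-c2cccc3c2CCC3c2ncc[nH]2)nc1`: 53%
Compound 2 `CNC(=O)c1cccc2c1CCC2c1ncc[nH]1`: 59%

Two compounds share the same core and differ only in one group on an aromatic carbon. In a functional assay on CHO cells for agonist activity at Alpha-1A adrenergic receptor (Homo sapiens), read by FLIPR and calcium flux (on this read-out higher numbers stand for larger maximal responses and lower numbers for smaller maximal responses), compound 1 gives 53%, and compound 2 gives 59%. Among the measured compounds shown here, the single step between them, a number 6 percentage points higher from compound 1 to compound 2 (within the scatter), is within the scatter, so the two numbers cannot be told apart. Compound 2 has the higher of the two numbers, with compound 1 the nearest, but that difference is not meaningful.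

Compound 3 `c1cc(-c2nccs2)c2c(c1)C(c1ncc[nH]1)CC2` carries the change (1,3-thiazol-2-yl in place of methylcarbamoyl on an aromatic carbon). For the measured compounds named here, the only measured step, a number 6 percentage points higher from compound 1 to compound 2 (within the scatter), swapped one group for another at this same position and left the maximal response essentially unchanged; compound 1 already carried an aromatic ring at this spot. On this basis the step from compound 2 to compound 3 in this assay is expected to stay within the scatter, a number 4 percentage points lower from compound 2 to compound 3 (within the scatter). Compound 3 is therefore estimated at 55%, between 40% and 70%.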

Compound 3, largest response reached (Emax), in percent of the reference or control that the assay uses: 64%
Estimate against measurement, compound 3: 9 percentage points below; the measured number falls inside the stated range.
By their numbers in this assay, from the lowest: compounds 1, 2 and 3 (each within the scatter of the next, the first and the last beyond it).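

In this assay, the exchange of methylcarbamoyl for 1,3-thiazol-2-yl gives a number 5 percentage points higher from compound 2 to compound 3 (within the scatter), so at this aromatic carbon a group with no ring and a group with a five-membered aromatic ring cannot be told apart, even though the hydrogen-bond donor of methylcarbamoyl is gone. The exchange of pyridin-2-yl for 1,3-thiazol-2-yl gives a number 11 percentage points higher from compound 1 to compound 3 (beyond the scatter), the only modest difference beyond the scatter in this set, and it arises between two aromatic rings rather than between a ring and an open group. No measurement here explains why these two rings differ.

The compounds shown leave open how a plain phenyl ring would read at this position, which would help show whether the hetero atoms of the ring matter at all. They also leave open whether the maximal response would hold with a carboxylic acid, an amine or a longer alkyl chain on this same carbon.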